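Removing benzyloxycarbonyl from compound 3

This account rests on a few compounds, and the source may have more. Where it says the series, first, only, none or still open, it means among the compounds named here.

In a functional assay on CCRF-CEM cells (Homo sapiens) for inhibition, with a stated time of 72 h (on this read-out lower numbers stand for stronger inhibition and higher numbers for weaker inhibition), compound 3 `COC(=O)C[C@H](NC(=O)OCc1ccccc1)C(=O)N(Cc1ccccc1)C1(C(=O)NCc2ccccc2)CCN(Cc2ccccc2)CC1` gives 4500 nM, the lower of the two true numbers in the series. Compound 1 `COC(=O)C[C@H](NC(=O)OC(C)(C)C)C(=O)N(Cc1ccccc1)C1(C(=O)NCc2ccccc2)CCN(Cc2ccccc2)CC1` gives 19000 nM, the nearest value. Compound 2 `CC(C)(C)OC(=O)N1CCC[C@H]1C(=O)N(Cc1ccccc1)C1(C(=O)NCc2ccccc2)CCN(Cc2ccccc2)CC1` gives > 50000 nM, which is a limit of the assay and not a number.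

Among the measured compounds shown here, the only measured step is a 4.2-fold lower number from compound 1 to compound 3 (0.63 log units; beyond the scatter). Compound 4 `COC(=O)C[C@H](N)C(=O)N(Cc1ccccc1)C1(C(=O)NCc2ccccc2)CCN(Cc2ccccc2)CC1` carries hydrogen in place of benzyloxycarbonyl on an amine nitrogen. For the measured compounds named here, no measured step removes this group outright, so the evidence is thin. The modest step of a 4.2-fold lower number from compound 1 to compound 3 (0.63 log units; beyond the scatter) shows that the group on that oxygen matters in this assay, and it suggests that losing the benzyl portion costs something. A move to a higher number is therefore expected, of similar size to that step or somewhat larger.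

The expected step is a 4.4-fold higher number from compound 3 to compound 4 (0.65 log units; beyond the scatter). Compound 4 is estimated at 20000 nM, with an expected range of 6000 nM to 50000 nM.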

Compound 4, half-maximal inhibitory concentration: 104000 nM
Estimate against measurement, compound 4: 5.2-fold (0.72 log units) below; the measured number lies above the stated range.
By their numbers in this assay, from the lowest: compound 3; then compound 1; then compound 4.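

In this assay, among the compounds shown here, the free amino compound gives the first direct reading of what a group on this amine nitrogen is worth: hydrogen in place of benzyloxycarbonyl gives a 23-fold higher number from compound 3 to compound 4 (1.36 log units; beyond the scatter), a large step, and hydrogen in place of tert-butoxycarbonyl gives a 5.5-fold higher number from compound 1 to compound 4 (0.74 log units; beyond the scatter), a modest one. Both groups therefore go with a lower number than hydrogen at this place, and the earlier comparison of compound 1 with compound 3 could not show this. The step from compound 2 to compound 4 cannot be read, as compound 2 carries a limit and not a number: the limit of > 50000 nM in this assay, at which 1 of the 4 values shown sits.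

The compounds shown do not separate the share of the aromatic ring in benzyloxycarbonyl from that of its carbonyl. An acetyl group on this amine nitrogen would bear on that question.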